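The source may hold more compounds than are shown below. What is called first, only, known or untested is meant among the compounds shown, and "the series" means these compounds.

Series notes. Compound 3 `CNC(=O)/C=C/c1ccncc1-c1ccc2ccccc2c1` is the higher of the two numbers reached in a functional assay on A549 cells (Homo sapiens) for inhibition, read by sulforhodamine B assay, with a stated time of 72 h (a lower number here means a stronger inhibitor of growth, a higher number a weaker inhibitor of growth), where compound 3 gives 6620 nM; compound 1 `CCOC(=O)/C=C/c1ccncc1-c1ccc2c(ccn2C)c1` sits lower at 1720 nM, a gap beyond the scatter. Compound 2 `O=C(O)CCc1ccncc1-c1ccc2ccccc2c1` reaches only a limit, > 10000 nM. For the measured compounds named here, the one measured step, an at least 1.5-fold lower number from compound 2 to compound 3 (0.17 log units; that floor lies within the scatter), has a floor within the scatter and rests on one end at the limit (the limit of > 10000 nM in this assay, at which 1 of the 3 values shown sits), so it settles little. Compound 4 `O=C(O)/C=C/c1ccncc1-c1ccc2ccccc2c1` differs from compound 3 by hydroxy in place of methylamino on a carbonyl carbon. Going by the values given here, no measured step shows hydroxy in place of methylamino on a carbonyl carbon; the only carboxy compound, compound 2, sits at the limit. Compound 4 is therefore expected to move back up by a 1.5-fold higher number from compound 3 to compound 4 (0.18 log units; within the scatter), likely beyond the scatter, and is estimated at 10000 nM within 4000 nM to 25000 nM.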

Compound 4, concentration for 50% growth inhibition: > 10000 nM
Compound 4: no number, only a limit (the forecaster's own chance of this, stated with the estimate: 50%); the middle value lies on the limit itself.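

Hydroxy in place of methylamino on a carbonyl carbon now has a measured step, an at least 1.5-fold higher number from compound 3 to compound 4 (0.17 log units; that floor lies within the scatter), but it gives only a floor. Compound 4 gives > 10000 nM, which is a limit and not a number. The step between compound 2 and compound 4 cannot be read, so the 2-carboxyethenyl and 2-carboxyethyl chains cannot be ranked, and the carboxy compounds both rest on the limit: the limit of > 10000 nM in this assay, at which 2 of the 4 values shown sit.

Still open, on these data alone, is where a primary amide or a dimethylamide at this carbonyl carbon would fall on the core of compound 3. As far as these compounds go, the true size of the step to the carboxylic acid also remains open.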